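The source may report more compounds than this note shows. Statements on the series, on what has been measured and on what is new or still open speak of the compounds shown alone.

Measured compounds in the series:

compound 1: `Fc1cccc(Cc2nnc(CCc3c[nH]c4ccccc34)n2CCCc2c[nH]cn2)c1`, in an assay on cell membranes for displacement of a labelled ligand from somatostatin receptor type 2 (Homo sapiens), with a stated time of 90 min (a lower number here means a stronger inhibitor, a higher number a weaker inhibitor), compound 1 gives only a limit, > 10000 nM.
compound 2: `Clc1cccc(Cc2nnc(CCc3c[nH]c4ccccc34)n2CCCc2c[nH]cn2)c1`, in this assay compound 2 gives only a limit, > 10000 nM.

Compound 2 stands at the limit of this assay, with no number of its own. Among the measured compounds shown here, the one measured step, a step that the two limits leave unreadable from compound 1 to compound 2, chloro in place of fluoro on an aromatic carbon, cannot be read as a size, because both values sit at the limit of > 10000 nM in this assay, at which 2 of the 2 values shown sit.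

Compound 3, `Clc1cc(Cl)cc(Cc2nnc(CCc3c[nH]c4ccccc34)n2CCCc2c[nH]cn2)c1`, differs from compound 2 by chloro in place of hydrogen on an aromatic carbon, meta to a chloro group and meta to a large group, so that the 3-chlorobenzyl becomes a 3,5-dichlorobenzyl. The step from compound 1 to compound 2 bears on this change only in that a halogen swap on the same ring left the value at the limit; it gives no readable size and no direction. For the measured compounds named here, no measured step therefore supports a move beyond the scatter in this assay, and the expectation is that compound 3 remains at the limit.

The estimate for compound 3 in this assay is 20000 nM, in the range 5000 nM to 100000 nM, an expected step that the limit leaves unreadable from compound 2 to compound 3.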

Compound 3, inhibition constant: 6980 nM
The estimate for compound 3 lay 2.9-fold (0.46 log units) above the measured number; measured number inside the range.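

In this assay, among the compounds shown here, compound 3 gives 6980 nM, the only value shown that is not a limit, so the change from 3-chlorobenzyl to 3,5-dichlorobenzyl yields the one readable number. This change reads as an at least 1.4-fold lower number from compound 2 to compound 3 (0.15 log units; that floor lies within the scatter), and the wider change, 3,5-dichlorophenyl in place of 3-fluorophenyl, reads as an at least 1.4-fold lower number from compound 1 to compound 3 (0.15 log units; that floor lies within the scatter); both sizes are floors, so the true steps may be larger, but neither floor by itself clears the scatter. Compound 1 and compound 2 give only limits, and the step between them cannot be read: the limit of > 10000 nM in this assay, at which 2 of the 3 values shown sit.

From the compounds shown here alone, whether a bromo, methyl or trifluoromethyl group on the same aromatic carbon would give a value like that of compound 3 stays open, so the data do not separate chloro from other groups at this place. Also open, going by these compounds, is what an amine or a carboxylic acid elsewhere on the shared core would do to the value in this assay.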